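Sulfonyl ring swap in a chemokine receptor binding series

The compounds below may be only part of what the source reports. "The series", "measured", "known", "first", "only" and "open" are said of these compounds alone.

Measured in an assay on MDA-MB-231 cells for binding affinity to C-X-C chemokine receptor type 4 (Homo sapiens), read by microscopy, with stated times of 10 min and 30 min; a lower number here means that less compound is needed, a higher number that more compound is needed for the effect:
compound 1 `O=C(NCc1ccc(CNS(=O)(=O)c2ccccc2)cc1)c1ccc(CNc2ncccn2)cc1`: 1 nM
compound 2 `O=C(NCc1ccc(CNS(=O)(=O)c2cccnc2)cc1)c1ccc(CNc2ncccn2)cc1`: > 1000 nM

Compound 2 stands at the limit of > 1000 nM in this assay, at which 1 of the 2 values shown sits, so for compound 2 only a limit and not a number is known. Compound 3 `O=C(NCc1ccc(CNS(=O)(=O)c2ccc(F)cc2)cc1)c1ccc(CNc2ncccn2)cc1` differs from compound 2 in one place: 4-fluorophenyl in place of pyridin-3-yl on a sulfonyl sulfur. Among the compounds with values here, the single measured step, an at least 1000-fold higher number from compound 1 to compound 2 (3.00 log units; beyond the scatter), runs the other way, from a ring of carbon only to pyridin-3-yl. Compound 3 brings back a ring of carbon only, so a large fall in the number is expected, an at least 500-fold lower number from compound 2 to compound 3 (2.69 log units; beyond the scatter). Compound 3 is therefore estimated at 2 nM, within 0.5 nM to 20 nM.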

Compound 3, effective concentration (reported as EC, without a stated level of effect): > 1000 nM
Compound 3: a limit, no number; the forecaster's own chance of this, stated with the estimate: 5%; middle value at least 500-fold (2.69 log units) away from the limit.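

Fluoro in place of hydrogen on an aromatic carbon, a single-atom change at this position, gives an at least 1000-fold higher number from compound 1 to compound 3 (3.00 log units; beyond the scatter). The large rise seen with pyridin-3-yl is therefore not confined to a ring with a hetero atom, since 4-fluorophenyl, a ring of carbon only, also gives a large rise. The step between compound 2 and compound 3 cannot be read, since both values are limits and not numbers: the limit of > 1000 nM in this assay, at which 2 of the 3 values shown sit.

Going by these compounds, how far compound 2 and compound 3 lie beyond that limit remains open. On these data alone, it is also open whether 4-chlorophenyl or 4-methylphenyl on the sulfonyl sulfur would stay close to compound 1.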